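Swapping 1-(trifluoromethyl)ethoxy for 4-fluorophenyl: notes on compound 4

The compounds below may be only part of what the source reports. "The series", "measured", "known", "first", "only" and "open" are said of these compounds alone.

Values in a physicochemical assay for solubility; on this read-out higher numbers stand for higher solubility and lower numbers for lower solubility:
- compound 1 `C[C@H](Oc1ccc(S(C)(=O)=O)cc1C(=O)N1Cc2ccccc2C1)C(F)(F)F`: < 1 ug/mL (a limit of the assay)
- compound 2 `C[C@H](Oc1ccc(S(C)(=O)=O)cc1C(=O)N1Cc2ccc(-c3ccccn3)cc2C1)C(F)(F)F`: 30 ug/mL
- compound 3 `C[C@H](Oc1ccc(S(C)(=O)=O)cc1C(=O)N1Cc2ccc(C3CCOCC3)cc2C1)C(F)(F)F`: 76 ug/mL
- compound 4 `CS(=O)(=O)c1ccc(-c2ccc(F)cc2)c(C(=O)N2Cc3ccc(C4CCOCC4)cc3C2)c1`: not yet measured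

Compound 3 holds the highest of the two numbers. The closest gap is a 2.5-fold higher number from compound 2 to compound 3 (0.40 log units; beyond the scatter), a modest step. The next change is 4-fluorophenyl in place of 1-(trifluoromethyl)ethoxy on an aromatic carbon, with 4-fluorophenyl in place of 1-(trifluoromethyl)ethoxy. Among the measured compounds shown here, no measured step touches the group that leaves here. The large steps of an at least 30-fold higher number from compound 1 to compound 2 (1.47 log units; beyond the scatter) and an at least 76-fold higher number from compound 1 to compound 3 (1.88 log units; beyond the scatter) show only that a single substitution can move this assay far. A lower number is expected, since compound 3 at 76 ug/mL tops the series, but this is weakly grounded. For compound 4 the expected value is 20 ug/mL, with an estimated range of 4 ug/mL to 80 ug/mL. That estimate means an expected 3.8-fold lower number from compound 3 to compound 4 (0.58 log units; beyond the scatter).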

Compound 4, solubility: 15 ug/mL
Compound 4: the middle estimate sits 1.3-fold (0.12 log units) above what was measured; the measured number falls inside the stated range.
By their numbers in this assay, from the lowest: compounds 4 and 2 (each within the scatter of the next); then compound 3. At a limit, below all of these: compound 1.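

Compound 1, compound 2 and compound 3 all carry 1-(trifluoromethyl)ethoxy at this position, ortho to a large group and para to a methylsulfonyl group, so its effect could not be read from them. In this assay the change to 4-fluorophenyl gives a 5.1-fold lower number from compound 3 to compound 4 (0.70 log units; beyond the scatter) with oxan-4-yl held constant, so the read-out moves beyond the scatter although both groups have the same heavy-atom count. Nothing at hand accounts for this step.

Going by these compounds, it remains open whether an amine or a carboxylic acid here would give a higher number. On these data alone, it is also open whether the step would hold with pyridin-2-yl in place of oxan-4-yl.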